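Aryl substituent on the cyclopropyl amide: methoxy to cyano

This account rests on a few compounds, and the source may have more. Where it says the series, first, only, none or still open, it means among the compounds named here.

Measured compounds:
compound 1 `CC[C@H](C)[C@@H](CN(C(=O)[C@@H]1C[C@H]1c1ccccc1)c1ccc(-c2ccccc2)cc1)NC(C)=O`: 5.8 nM
compound 2 `CC[C@@H](C)[C@H](N)CN(C(=O)[C@@H]1C[C@H]1c1ccccc1)c1ccc(-c2ccccc2)cc1`: 1.4 nM
compound 3 `CC[C@H](C)[C@H](N)CN(C(=O)[C@@H]1C[C@H]1c1ccc(OC)cc1)c1ccc(-c2ccccc2)cc1`: > 25000 nM

In a functional assay for agonist activity at G protein-coupled receptor 88 (Homo sapiens), read by HTRF and cAMP accumulation (a lower number here means that less compound is needed, a higher number that more compound is needed for the effect), compound 3 gives only a limit, > 25000 nM, and no number (the limit of > 25000 nM in this assay, at which 1 of the 3 values shown sits). Compound 4 `CC[C@H](C)[C@H](N)CN(C(=O)[C@@H]1C[C@H]1c1ccc(C#N)cc1)c1ccc(-c2ccccc2)cc1` differs from compound 3 by cyano in place of methoxy on an aromatic carbon. Among the compounds with values here, the only measured step, a 4.1-fold lower number from compound 1 to compound 2 (0.62 log units; beyond the scatter), concerns the amine-bearing chain and not the aryl substituent, so it does not bear on this change; compound 2 and compound 3 differ in more than one place and give no step either. Within the data shown here, no measured step therefore informs the expected direction in this assay for compound 4. Compound 4 is expected to stay near the limit, estimated at 20000 nM (range 2000 nM to 100000 nM), an expected step of an at least 1.2-fold lower number from compound 3 to compound 4 (0.09 log units; that floor lies within the scatter).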

Compound 4, half-maximal effective concentration: > 25000 nM
Compound 4 gave a limit, no number; the forecaster's own chance of this, stated with the estimate: 60%; middle value at least 1.2-fold (0.09 log units) from the limit.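

Within the data shown here, compound 3 and compound 4 both give only a limit, not a number, in this assay, so no step between them can be read: the limit of > 25000 nM in this assay, at which 2 of the 4 values shown sit. On these data alone, whether cyano and methoxy differ at all in this assay remains open.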